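Dropping the fluoro from compound 1

A few compounds are considered here, and "the series" means these few. Any claim that something is new, unique, unknown or untested is made for them only; others in the source may bear on it.

Compound 1 `Fc1ccc(-n2c(S)nnc2Sc2nnc(-c3ccccc3)n2-c2ccccc2)cc1` gives the highest of the three numbers in a functional assay on HT-29 cells (Homo sapiens) for inhibition, read by MTT assay, with a stated time of 48 h (a higher number here means a weaker inhibitor, a lower number a stronger inhibitor), with 32800 nM; compound 3 `COc1ccc(-n2c(S)nnc2CSc2nnc(-c3ccccc3)n2-c2ccccc2)cc1` gives 27700 nM and compound 2 `Sc1nnc(CSc2nnc(-c3ccccc3)n2-c2ccccc2)n1-c1ccccc1` gives 5490 nM. Compound 4 `Sc1nnc(Sc2nnc(-c3ccccc3)n2-c2ccccc2)n1-c1ccccc1` differs from compound 1 in one place: hydrogen in place of fluoro on an aromatic carbon. For the measured compounds named here, the only measured step with a bearing on this change is a 5.0-fold higher number from compound 2 to compound 3 (0.70 log units; beyond the scatter), and it is an imperfect guide, since it adds a different group and the two pairs differ in their linkers. If removing a substituent on that ring undoes such a rise, a modest fall would be expected. Compound 4 is therefore estimated at 15000 nM, within 5000 nM to 45000 nM, a step of a 2.2-fold lower number from compound 1 to compound 4 (0.34 log units; beyond the scatter) that is expected.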

Compound 4, half-maximal inhibitory concentration: 28300 nM
Estimate against measurement, compound 4: 1.9-fold (0.28 log units) below; the measured number falls inside the stated range.
By their numbers in this assay, from the lowest: compound 2; then compounds 3, 4 and 1 (each within the scatter of the next).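

In this assay, 4-fluorophenyl to phenyl gives a 1.2-fold lower number from compound 1 to compound 4 (0.06 log units; within the scatter), so at this place on the aromatic ring, fluoro and hydrogen cannot be told apart. The earlier compounds had shown a change on this ring only as a 5.0-fold higher number from compound 2 to compound 3 (0.70 log units; beyond the scatter), with methoxy and on a different linker. No measurement offers an explanation for this result. The compounds shown leave open whether an amine or a carboxylic acid at this place would shift the number, and whether fluoro would give the same result on the linker of compound 2.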